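A few compounds are considered here, and "the series" means these few. Any claim that something is new, unique, unknown or untested is made for them only; others in the source may bear on it.

In an ADME assay on L929 cells (Mus musculus) for cytotoxicity, read by resazurin assay, with a stated time of 72 h (a higher number here means a weaker inhibitor, a lower number a stronger inhibitor), compound 2 `O=C(/C=C/c1ccc2c(c1)B(O)OC2)c1ccccc1` gives > 10 ug/mL, which is a limit of the assay and not a number. Compound 1 `COCOc1cccc(C(=O)/C=C/c2ccc3c(c2)B(O)OC3)c1` also reaches only a limit, > 10 ug/mL. The picture so far is therefore (the limit of > 10 ug/mL in this assay, at which 2 of the 2 values shown sit), and no exact value is available for either compound.

Compound 3 `Cc1cccc(C(=O)/C=C/c2ccc3c(c2)B(O)OC3)c1` differs from compound 2 by one small change, methyl in place of hydrogen on an aromatic carbon.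

Among the compounds with values here, the one measured step that bears on this change is a step that the two limits leave unreadable from compound 1 to compound 2. It offers no size to carry over, so no step beyond the scatter is expected in this assay, and another limit is the likeliest report. The expected change is a step that the limit leaves unreadable from compound 2 to compound 3. For compound 3, the estimated value is 20 ug/mL, with an expected range from 9 ug/mL to 60 ug/mL.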

Compound 3, half-maximal inhibitory concentration: 8.56 ug/mL
Compound 3: the middle estimate sits 2.3-fold (0.37 log units) above what was measured; the measured number lies below the stated range.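

In this assay, compound 3, the 3-methylphenyl member, gives 8.56 ug/mL, the only exact value among the compounds shown. Methyl in place of hydrogen gives an at least 1.1-fold lower number from compound 2 to compound 3 (0.06 log units; that floor lies within the scatter), and methyl in place of methoxymethoxy gives an at least 1.1-fold lower number from compound 1 to compound 3 (0.06 log units; that floor lies within the scatter), so this position can carry a small group with a readable result, but neither floor proves a real change. Compound 1 and compound 2 each remain at a limit of the assay rather than a number: the limit of > 10 ug/mL in this assay, at which 2 of the 3 values shown sit.

From the compounds shown here alone, how far the true values of compound 1 and compound 2 lie past that limit stays open, and with it the real size of both steps. Also open, going by these compounds, is what an amine, a carboxylic acid or a longer chain at this position would give.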